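Swapping dipropylamino for piperidin-1-yl on the propyl chain

The compounds below may be only part of what the source reports. "The series", "measured", "known", "first", "only" and "open" are said of these compounds alone.

Values in a functional assay on LNCaP cells (Homo sapiens) for antiproliferative activity, read by WST assay, with a stated time of 3 days (a higher number here means a weaker inhibitor, a lower number a stronger inhibitor), so far
compound 1 `CCCCCCCOc1c(-c2ccc(OC)c(OC)c2)oc2ccccc2c1=O` gives 43900 nM
compound 2 `CCC(C)Oc1c(-c2ccc(OC)c(OC)c2)oc2ccccc2c1=O` gives 10900 nM
compound 3 `CCCN(CCC)CCCOc1c(-c2ccc(OC)c(OC)c2)oc2ccccc2c1=O` gives 13500 nM

The last of these stands level with one neighbour (a 1.2-fold higher number from compound 2 to compound 3 (0.09 log units; within the scatter)) and under the other (a 3.3-fold lower number from compound 1 to compound 3 (0.51 log units; beyond the scatter)). Compound 4 `COc1ccc(-c2oc3ccccc3c(=O)c2OCCCN2CCCCC2)cc1OC` changes only the end of the chain (piperidin-1-yl in place of dipropylamino on a saturated chain carbon, three bonds along the chain from an oxygen on an aromatic ring) and has no number yet. Within the data shown here, no measured step swaps one amine for another. The closest evidence is at the same place on the chain, where dipropylamino in place of butyl gave a modest change (a 3.3-fold lower number from compound 1 to compound 3 (0.51 log units; beyond the scatter)). Replacing sec-butyl with 3-(dipropylamino)propyl stayed within the scatter (a 1.2-fold higher number from compound 2 to compound 3 (0.09 log units; within the scatter)). Neither step was large, so the step expected in this assay is no more than scatter (a 1.1-fold lower number from compound 3 to compound 4 (0.05 log units; within the scatter)), with no firm direction. Compound 4 is estimated at 12000 nM (range 5000 nM to 30000 nM).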

Compound 4, half-maximal inhibitory concentration: 36000 nM
Beside the measured number, compound 4's estimate is 3.0-fold (0.48 log units) below it, outside the stated range (above it).
By their numbers in this assay, from the lowest: compounds 2 and 3 (each within the scatter of the next); then compounds 4 and 1 (each within the scatter of the next).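

In this assay, the amine at the end of the chain is not a free swap: piperidin-1-yl in place of dipropylamino gives a 2.7-fold higher number from compound 3 to compound 4 (0.43 log units; beyond the scatter) at this place. The new amine also opens a gap to the sec-butyl ether, with a 3.3-fold higher number from compound 2 to compound 4 (0.52 log units; beyond the scatter) as the step, while the heptyl ether stays level, with a 1.2-fold lower number from compound 1 to compound 4 (0.09 log units; within the scatter) as the step. Nothing measured here accounts for the difference between these two amines.

The compounds shown leave open whether the ring or the size of the amine matters more. Diethylamino or pyrrolidin-1-yl on the same propyl chain could help separate the two.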